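This account rests on a few compounds, and the source may have more. Where it says the series, first, only, none or still open, it means among the compounds named here.

Measured in a toxicity assay on HEK-293T cells (Homo sapiens) for cytotoxicity, read by MTT assay, with a stated time of 72 h; a higher number here means a weaker inhibitor, a lower number a stronger inhibitor:

- Compound 1 `CN(C)CCCCCn1c2c(c3ccccc31)C(=O)c1c[n+]([O-])c3ccccc3c1C2=O`: 70 nM
- Compound 2 `O=C1c2c[n+]([O-])c3ccccc3c2C(=O)c2c1c1ccccc1n2Cc1cn([C@H]2O[C@H](CO)[C@@H](O)[C@H]2O)nn1`: 1370 nM

Of these two, compound 1 stands lowest with 70 nM, making it the stronger inhibitor here. Compound 2 lies at 1370 nM, and this gap is beyond the usual scatter. For the measured compounds named here, the two compounds differ in more than one place, so they give no clean single-change step.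

Compound 3 `O=C1c2c[n+]([O-])c3ccccc3c2C(=O)c2c1c1ccccc1n2CCCCn1ccnc1` has not yet been measured. It shares the core of compound 1, and the change lies in the side chain: 1H-imidazol-1-yl in place of (dimethylamino)methyl on a saturated chain carbon, four bonds along the chain from an aromatic nitrogen. In words, 1H-imidazol-1-yl stands in place of (dimethylamino)methyl on a saturated chain carbon, four bonds along the chain from an aromatic nitrogen.

Going by the values given here, no measured pair isolates this change, so any forecast is uncertain. Among the compounds with values here, the only guide is that compound 2, which also lacks the dimethylamino group, gives 1370 nM. A rise in the number is therefore expected, with the estimated change being a 3.6-fold higher number from compound 1 to compound 3 (0.55 log units; beyond the scatter). The estimated value for compound 3 is 250 nM, with an expected range from 60 nM to 1100 nM.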

Compound 3, half-maximal inhibitory concentration: 280 nM
Compound 3: the middle estimate sits 1.1-fold (0.05 log units) below what was measured; measured number inside the range.
By their numbers in this assay, from the lowest: compound 1; then compound 3; then compound 2.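

In this assay, for the compounds shown here, the exchange of (dimethylamino)methyl for 1H-imidazol-1-yl on a saturated chain carbon, four bonds along the chain from an aromatic nitrogen, gives a 4.0-fold higher number from compound 1 to compound 3 (0.60 log units; beyond the scatter), a modest step but the first single-change reading at this position. Compound 1 and compound 2 differ in more than one place and could not show this; the new pair shows that the number responds to the group held on this chain, and that a five-membered aromatic ring with 2 hetero atoms can stand there while compound 3 still gives 280 nM. No measurement at hand accounts for the size or direction of this step.

As far as these compounds go, with a single step, it remains open whether the higher number follows from the loss of the dimethylamino group, from the entry of the ring, or from both, since the change can also be read as 4-(dimethylamino)butyl to 3-(1H-imidazol-1-yl)propyl. From the compounds shown here alone, how a morpholine or a piperidine would read on this chain also stays open, as does the effect of a longer chain carrying 1H-imidazol-1-yl.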